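Solubility notes: fluoro added to the 3-chlorophenyl arm

This account rests on a few compounds, and the source may have more. Where it says the series, first, only, none or still open, it means among the compounds named here.

Compound 1 `Cc1cc(NCc2ccccn2)n2ncc(-c3ccc(F)cc3)c2n1`: < 5000 nM in a physicochemical assay for solubility, read by HPLC, using the shake flask method, measured as kinetic solubility, with a stated time of 2 h, at pH 7.4; a higher number here means a more soluble compound, a lower number a less soluble compound
Compound 2 `Cc1ccc(-c2cnn3c(NCc4ccccn4)cc(C)nc23)cc1`: < 5000 nM in this assay
Compound 3 `Cc1cc(NCc2ccccn2)n2ncc(-c3cccc(Cl)c3)c2n1`: < 5000 nM in this assay

Compound 3 stands only at a limit of this assay, not at a number. The same holds for compound 1, and for compound 2, so all three measured values sit at the limit (the limit of < 5000 nM in this assay, at which 3 of the 3 values shown sit). The three steps among them, a step that the two limits leave unreadable from compound 1 to compound 2, a step that the two limits leave unreadable from compound 1 to compound 3 and a step that the two limits leave unreadable from compound 2 to compound 3, therefore carry no readable size; the change of the aryl group from fluoro to methyl to chloro, in these three compounds, leaves no trace that can be seen in this assay.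

Compound 4 `Cc1cc(NCc2ccccn2)n2ncc(-c3ccc(F)c(Cl)c3)c2n1` differs from compound 3 by fluoro in place of hydrogen on an aromatic carbon; cut one bond further out, the change reads 3-chlorophenyl to 3-chloro-4-fluorophenyl. Going by the values given here, no measured step bears on this change with a readable size, since each of the three sits at the limit. The expectation can only rest on the limit itself: the expected step is a step that the limit leaves unreadable from compound 3 to compound 4, and it is most likely that the assay again returns only a limit. Compound 4 is expected at 2000 nM, within a range from 300 nM to 5000 nM.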

Compound 4, solubility: < 5000 nM
Compound 4 was reported as a limit; the forecaster's own chance of this, stated with the estimate: 85%; the middle value does not contradict the limit.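

Compound 4 returns only a limit in this assay, as do compound 1, compound 2 and compound 3, so none of the new steps to compound 4 can be read: the limit of < 5000 nM in this assay, at which 4 of the 4 values shown sit.

The compounds shown leave open where compound 1, compound 2, compound 3 and compound 4 stand as numbers, and whether any of these aryl changes shifts the read-out.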